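Lengthening an ester chain by one carbon

A few compounds are considered here, and "the series" means these few. Any claim that something is new, unique, unknown or untested is made for them only; others in the source may bear on it.

Compound 1 `O=C1C2=C(CCCC2)C(=O)N1c1ccc(Cl)cc1F` gives 240 nM
Compound 2 `CCOC(=O)c1cc(N2C(=O)C3=C(CCCC3)C2=O)c(F)cc1Cl` gives 87.1 nM

In a functional assay on the whole organism with Scenedesmus acutus as the target, with a stated time of 20 h (a higher number here means a weaker inhibitor, a lower number a stronger inhibitor), compound 2 gives 87.1 nM and so holds the lower of the two numbers, which makes it the stronger inhibitor. Compound 3 `CCCOC(=O)c1cc(N2C(=O)C3=C(CCCC3)C2=O)c(F)cc1Cl` differs from compound 2 only in the ester chain, by methyl in place of hydrogen on a saturated chain carbon, two bonds along the chain from an oxygen next to a carbonyl group so that ethoxy becomes propoxy. Among the measured compounds shown here, the one measured step that bears on this is a 2.8-fold lower number from compound 1 to compound 2 (0.44 log units; beyond the scatter) for ethoxycarbonyl in place of hydrogen on an aromatic carbon. That step was modest, though beyond the scatter, and it brought in the whole ester group, while the new change only lengthens it. For the measured compounds named here, no measured pair tests chain length, so in this assay no step beyond the scatter is expected in either direction. The step expected is a 1.1-fold lower number from compound 2 to compound 3 (0.04 log units; within the scatter) on present evidence. Compound 3 is expected at 80 nM with 35 nM to 190 nM as the estimated range.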

Compound 3, half-maximal inhibitory concentration: 66.1 nM
Compound 3: middle estimate off by 1.2-fold (0.08 log units), on the high side; the range from low to high includes it.
By their numbers in this assay, from the lowest: compounds 3 and 2 (each within the scatter of the next); then compound 1.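

In this assay, lengthening ethoxy to propoxy gives a 1.3-fold lower number from compound 2 to compound 3 (0.12 log units; within the scatter), so the two numbers cannot be told apart and the added methyl at the end of the ester chain brings no real difference. Set against hydrogen, the whole propoxycarbonyl group gives a 3.6-fold lower number from compound 1 to compound 3 (0.56 log units; beyond the scatter), which shows that the step beyond the scatter seen with ethoxycarbonyl survives in an ester with a longer chain. Nothing measured here speaks to the reason for either step.

Two ester chains are too few to show a trend with length, so a butoxy or longer chain, or a branched one such as isopropoxy, could keep this level or lose it. Also open, on these data alone, is whether the ester itself matters, a question that a carboxylic acid or an amide in its place would address.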